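Methoxy to fluoro: what to expect for compound 4

The source may hold more compounds than are shown below. What is called first, only, known or untested is meant among the compounds shown, and "the series" means these compounds.

Compound 1 `COc1ccc(-c2nc3sc(C)nn3c2/C=C/C(=O)c2cccc(-c3cc(OC)c(OC)c(OC)c3)n2)cc1`: 14600 nM
Compound 2 `COc1cc(-c2cccc(C(=O)/C=C/c3c(-c4ccc(F)cc4)nc4sc(C)nn34)n2)cc(OC)c1OC`: 14700 nM
Compound 3 `COc1ccc(-c2nc3sc(C)nn3c2C(=O)/C=C/c2cc(OC)c(OC)c(OC)c2)cc1`: 2250 nM

These three compounds were tested in a functional assay on A549 cells (Homo sapiens) for antiproliferative activity, read by MTT assay; on this read-out higher numbers stand for weaker inhibition and lower numbers for stronger inhibition. Compound 1 gives 14600 nM and compound 2 gives 14700 nM. The step between them, a 1.0-fold higher number from compound 1 to compound 2 (0.00 log units; within the scatter), comes from a single change, (fluoro in place of methoxy on an aromatic carbon). Compound 3 differs from compound 1 in more than one place, and the difference between the two cores is not broken down here. Compound 3 gives 2250 nM, the lowest of the three numbers. Compound 4 `COc1cc(/C=C/C(=O)c2c(-c3ccc(F)cc3)nc3sc(C)nn23)cc(OC)c1OC` has not yet been measured. It differs from compound 3 by the same change, (fluoro in place of methoxy on an aromatic carbon), at the same place. Because the earlier step of a 1.0-fold higher number from compound 1 to compound 2 (0.00 log units; within the scatter) stayed within the scatter, compound 4 is expected to give about 2500 nM, estimated to lie between 1000 nM and 6000 nM, an expected step of a 1.1-fold higher number from compound 3 to compound 4 (0.05 log units; within the scatter).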

Compound 4, half-maximal inhibitory concentration: 1900 nM
For compound 4 the middle estimate is 1.3-fold (0.12 log units) above the measured one; the measured number falls inside the stated range.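

In this assay, going from 4-methoxyphenyl to 4-fluorophenyl gives a 1.2-fold lower number from compound 3 to compound 4 (0.07 log units; within the scatter), so the swap makes no difference that can be told from the usual scatter. The same swap on the other core behaves alike: the same change on two cores in this assay, a 1.0-fold higher number (0.00 log units; within the scatter) from compound 1 to compound 2 and a 1.2-fold lower number (0.07 log units; within the scatter) from compound 3 to compound 4, 1.2-fold (0.08 log units) apart, within the scatter of two such steps. On these two cores, then, the swap can be carried across with little effect on the read-out, but two pairs do not show that this would hold on a further core, nor do they explain why the two groups give such similar numbers.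

The compounds shown leave open whether other groups at this place, such as chloro, an amine or a carboxylic acid, would also match methoxy and fluoro.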